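The compounds below may be only part of what the source reports. "The series", "measured", "known", "first", "only" and "open" are said of these compounds alone.

In a functional assay on BGC-823 cells (Homo sapiens) for antiproliferative activity, read by MTT assay (a lower number here means a stronger inhibitor, a higher number a weaker inhibitor), compound 1 (`CCCSc1ncnc2ccc(I)cc12`) gives 29000 nM. This lies within the scatter of compound 3 (`COc1cc(-c2nnc(Sc3ncnc4ccc(I)cc34)s2)cc(OC)c1OC`) at 19000 nM, while compound 2 (`COc1cc(-c2nnc(Sc3ncnc4ccccc34)s2)cc(OC)c1OC`) gives a higher number, 61200 nM, beyond the scatter. Compound 4 (`C=CCSc1ncnc2ccc(I)cc12`) departs from compound 1 by one change: vinyl in place of ethyl on a saturated chain carbon bound to a sulfur, or propylsulfanyl to allylsulfanyl. Within the data shown here, the only measured step, a 3.2-fold lower number from compound 2 to compound 3 (0.51 log units; beyond the scatter), is iodo in place of hydrogen on an aromatic carbon, a different change that offers only weak guidance here. No step beyond the scatter is therefore expected, and the expected step is a 1.2-fold lower number from compound 1 to compound 4 (0.06 log units; within the scatter). For compound 4 the estimated value is 25000 nM, with an expected range of 11000 nM to 55000 nM.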

Compound 4, half-maximal inhibitory concentration: 33200 nM
The estimate for compound 4 lay 1.3-fold (0.12 log units) below the measured number; low and high end bracket the measured number.
By their numbers in this assay, from the lowest: compounds 3, 1, 4 and 2 (each within the scatter of the next, the first and the last beyond it).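

In this assay the change from propylsulfanyl to allylsulfanyl gives a 1.1-fold higher number from compound 1 to compound 4 (0.06 log units; within the scatter) and so stays within the scatter. At this saturated chain carbon bound to a sulfur, vinyl in place of ethyl therefore leaves the number effectively unchanged, which the iodo step elsewhere on the core could not show. The data offer no explanation for this result.

The compounds shown leave open whether a longer chain or a terminal amine at this position would move the number beyond the scatter. They also leave open whether the allylsulfanyl group would behave the same way on the core without iodo.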